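This account rests on a few compounds, and the source may have more. Where it says the series, first, only, none or still open, it means among the compounds named here.

Measured so far in an ADME assay on BJ cells (Homo sapiens), read by MTT assay, with a stated time of 72 h; on this read-out lower numbers stand for stronger inhibition and higher numbers for weaker inhibition:

Compound 1 `Cc1nc(N)c2c(-c3cccs3)cn([C@@H]3O[C@H](CO)[C@@H](O)[C@H]3O)c2n1`: > 100000 nM, a limit of the assay rather than a number.
Compound 2 `CSc1ncnc2c1c(-c1ccoc1)cn2[C@@H]1O[C@H](CO)[C@@H](O)[C@H]1O`: 98800 nM.
Compound 3 `Cc1nc(N)c2c(-c3ccoc3)cn([C@@H]3O[C@H](CO)[C@@H](O)[C@H]3O)c2n1`: > 100000 nM, again a limit of the assay rather than a number.

Compound 2 is thus the only one of the three for which this assay returns a number; the other two values are limits. The step from compound 3 to compound 1 is a step that the two limits leave unreadable from compound 3 to compound 1, a change described as thiophen-2-yl in place of furan-3-yl on an aromatic carbon. Its size cannot be read because the limit of > 100000 nM in this assay, at which 2 of the 3 values shown sit, holds both ends of that pair.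

Compound 4 `CSc1ncnc2c1c(-c1cccs1)cn2[C@@H]1O[C@H](CO)[C@@H](O)[C@H]1O` has not yet been measured in this assay. It differs from compound 2 by thiophen-2-yl in place of furan-3-yl on an aromatic carbon, the same change that separates compound 3 from compound 1; the surroundings of the place are described in the same words for both pairs, so it is the same change made on a different core. How the core of compound 2 differs from the core of compound 3 is not broken down here.

The step from compound 2 to compound 4 in this assay is expected to be a 1.0-fold higher number from compound 2 to compound 4 (0.01 log units; within the scatter), close to nothing, because compound 2 already sits at 98800 nM in this assay and the same change on the other core left both members of the pair at the limit of > 100000 nM in this assay, at which 2 of the 3 values shown sit. Compound 4 is therefore estimated at 100000 nM in this assay, in a range from 30000 nM to 300000 nM, with a fair chance that the assay reports only a limit.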

Compound 4, half-maximal inhibitory concentration: 96900 nM
Estimate against measurement, compound 4: 1.0-fold (0.01 log units) above; measured number inside the range.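

In this assay the new pair gives a 1.0-fold lower number from compound 2 to compound 4 (0.01 log units; within the scatter) for thiophen-2-yl in place of furan-3-yl on an aromatic carbon, so on the core of compound 2 the change leaves no mark beyond the scatter. The same change on the core of compound 3 offers no size to set against this, and its step cannot be read, because compound 3 and compound 1 are both recorded as limits rather than numbers: the limit of > 100000 nM in this assay, at which 2 of the 4 values shown sit. For the compounds shown here, the result therefore shows that the swap makes no readable difference on one core, but it does not show that the change carries over from one core to another, as only one of the two pairs has a readable size.

All the compounds shown carry either furan-3-yl or thiophen-2-yl at this place, so it remains open whether an amine, a carboxylic acid or a longer chain there would move the read-out in this assay away from the top of its range. No pair shown differs in the core alone, which also leaves open what the difference between the two cores does to this read-out.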